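The source may report more compounds than this note shows. Statements on the series, on what has been measured and on what is new or still open speak of the compounds shown alone.

Measured so far in a functional assay on MGC-803 cells (Homo sapiens) for cytotoxicity, read by MTT assay, with a stated time of 38 h; a lower number here means a stronger inhibitor, a higher number a weaker inhibitor:
- compound 1 `COc1cc(OC)c2c(=O)c(OCC(=O)N/N=C/c3sccc3C)c(-c3cc(OC)c(OC)c(OC)c3)oc2c1`: 7740 nM
- compound 2 `COc1cc(OC)c2c(=O)c(OCC(=O)N/N=C/c3ccc[nH]3)c(-c3cc(OC)c(OC)c(OC)c3)oc2c1`: 5610 nM

Within the data shown here, compound 2 has only one measured neighbour, and the two values lie within the scatter of each other, so neither ranks ahead. Among the measured compounds shown here, the only measured step is a 1.4-fold lower number from compound 1 to compound 2 (0.14 log units; within the scatter). It places 1H-pyrrol-2-yl where 3-methylthiophen-2-yl stood.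

Compound 3 `COc1cc(OC)c2c(=O)c(OCCCN3CCCC3)c(-c3cc(OC)c(OC)c(OC)c3)oc2c1` is still to be measured in this assay. The change is a group of 7 heavy atoms (6 carbon, 1 nitrogen; one five-membered non-aromatic ring with 1 hetero atom) in place of a group of 10 heavy atoms (6 carbon, 3 nitrogen, 1 oxygen; one five-membered aromatic ring with 1 hetero atom), on a saturated chain carbon bound to an oxygen on an aromatic ring, and the entering group is 2-(pyrrolidin-1-yl)ethyl. For the measured compounds named here, the measured step touches only a part of the group that leaves, and no measurement yet shows what replacing that whole group does. It therefore bears on this change only weakly, and the data give no firm direction.

The expected change is a 1.6-fold higher number from compound 2 to compound 3 (0.21 log units; within the scatter), a modest move to a higher number that remains an estimate with wide uncertainty. The anchor is compound 2 at 5610 nM. For compound 3 the estimated value is 9000 nM, with an expected range from 3000 nM to 28000 nM.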

Compound 3, half-maximal inhibitory concentration: 32100 nM
Estimate against measurement, compound 3: 3.6-fold (0.55 log units) below, outside the stated range (above it).
By their numbers in this assay, from the lowest: compounds 2 and 1 (each within the scatter of the next); then compound 3.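

In this assay, putting 2-(pyrrolidin-1-yl)ethyl in place of the whole group on the saturated chain carbon bound to an oxygen on an aromatic ring gives a 5.7-fold higher number from compound 2 to compound 3 (0.76 log units; beyond the scatter) and, from the 3-methylthiophen-2-yl member, a 4.1-fold higher number from compound 1 to compound 3 (0.62 log units; beyond the scatter) in the same direction. Compound 3 therefore shows that this position can respond to a change beyond the scatter, whereas the earlier exchange of the two aromatic end groups, a 1.4-fold lower number from compound 1 to compound 2 (0.14 log units; within the scatter), stayed within it. Nothing measured here accounts for the rise in the number.

The replacement alters the whole group at once, so the compounds shown do not separate the loss of the aromatic ring, the carbon-nitrogen double bond and the amide carbonyl from the arrival of the pyrrolidine ring. A morpholine or dimethylamino group on the same chain, a longer chain ending in pyrrolidine, or a simple pyrrolidine amide would show whether the higher number follows the amine, the chain or the absence of the leaving group's parts.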